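A thiophen-2-yl sulfonamide and its expected cytotoxicity

The compounds below may be only part of what the source reports. "The series", "measured", "known", "first", "only" and "open" are said of these compounds alone.

Two sulfonamides have so far been tested in an ADME assay on HEK293 cells (Homo sapiens) for cytotoxicity, read by resazurin assay, with a stated time of 48 h; on this read-out lower numbers stand for higher toxicity in this test and higher numbers for lower toxicity in this test. Compound 1 `Cc1ccc(S(=O)(=O)Nc2ccc(-c3nc4ccccc4o3)cc2)cc1` gives 88000 nM in this assay. Compound 2 `C=Cc1ccc(S(=O)(=O)Nc2ccc3oc(-c4ccccc4)nc3c2)cc1`, built on the same shared core but with the sulfonamide attached differently, gives 53000 nM. That is the lower of the two numbers, yet its gap to compound 1 lies within the scatter, so the two compounds are treated as alike in this assay rather than ranked.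

Compound 3 `O=S(=O)(Nc1ccc2oc(-c3ccccc3)nc2c1)c1cccs1` has not yet been measured. It differs from compound 2 in a single place: thiophen-2-yl in place of 4-vinylphenyl on a sulfonyl sulfur. Among the measured compounds shown here, no pair of measured compounds shares this change, so no measured step gives the direction. Because compound 1 at 88000 nM and compound 2 at 53000 nM sit close together despite larger differences between them, the account expects the step to compound 3 to stay within the scatter, with no change in direction claimed. For compound 3 the expected value in this assay is 60000 nM, within a range of 25000 nM to 150000 nM. That estimate implies a step of a 1.1-fold higher number from compound 2 to compound 3 (0.05 log units; within the scatter), expected to be no larger than the scatter.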

Compound 3, half-maximal cytotoxic concentration: 97000 nM
Compound 3: middle estimate off by 1.6-fold (0.21 log units), on the low side; the measured number falls inside the stated range.
By their numbers in this assay, from the lowest: compounds 2, 1 and 3 (each within the scatter of the next).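

In this assay, among the compounds shown here, putting thiophen-2-yl in place of 4-vinylphenyl on a sulfonyl sulfur gives a 1.8-fold higher number from compound 2 to compound 3 (0.26 log units; within the scatter), the first step that can be read between compounds differing in one place. It shows that a five-membered aromatic ring with one hetero atom can stand on this sulfonyl sulfur in place of a six-membered aromatic ring of carbon only, with 5 heavy atoms instead of 8 and no double bond outside the ring, while the two compounds remain alike in this read-out. No measured evidence is available that bears on this result.

The compounds shown leave open whether an amine, a carboxylic acid or a longer chain on the sulfonyl sulfur would also stay within the scatter of compound 2 or would give a step beyond it. They also leave open whether thiophen-2-yl would give a similarly small step on the core of compound 1, where the sulfonamide is attached differently.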